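The compounds below may be only part of what the source reports. "The series", "measured", "known", "first", "only" and "open" are said of these compounds alone.

Measured so far:
Compound 1, `CCCCOC(=O)NS(=O)(=O)c1ccc(CCC)cc1-c1ccc(Cn2c(C(C)C)nc3ccccc32)cc1`, gives 4 nM in an assay on membranes from HEK293 cells for displacement of a labelled ligand from Type-2 angiotensin II receptor (Homo sapiens), read by radioligand binding; on this read-out lower numbers stand for stronger inhibition and higher numbers for weaker inhibition.
Compound 2, `CCCCOC(=O)NS(=O)(=O)c1ccc(CCC)cc1-c1ccc(Cn2c(-c3nccs3)nc3ccccc32)cc1`, gives 5.1 nM in this assay.

Compound 2 has the higher of these two numbers, but its gap to compound 1 lies within the scatter. Compound 3, `CCCCOC(=O)NS(=O)(=O)c1ccc(CCC)cc1-c1ccc(Cn2c(-c3ccccc3)nc3ccccc32)cc1`, has not been measured. Its change from compound 2 is phenyl in place of 1,3-thiazol-2-yl on an aromatic carbon. Among the measured compounds shown here, the one measured step that bears on this, a 1.3-fold higher number from compound 1 to compound 2 (0.11 log units; within the scatter), also replaced the group on that aromatic carbon and stayed within the scatter. A similar outcome is therefore expected in this assay, with no step beyond the scatter, a 1.0-fold lower number from compound 2 to compound 3 (0.01 log units; within the scatter). Compound 3 is estimated at 5 nM, within a range from 2 nM to 12 nM.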

Compound 3, inhibition constant: 590 nM
Compound 3: the middle estimate sits 120-fold (2.07 log units) below what was measured; the measured number lies above the stated range.
By their numbers in this assay, from the lowest: compounds 1 and 2 (each within the scatter of the next); then compound 3.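

In this assay, this aromatic carbon between two ring nitrogen atoms turns out not to accept every group equally: phenyl brings a 120-fold higher number from compound 2 to compound 3 (2.06 log units; beyond the scatter) and a 150-fold higher number from compound 1 to compound 3 (2.17 log units; beyond the scatter) in the same assay. Isopropyl and 1,3-thiazol-2-yl had looked interchangeable, so that pair hid how much the result can depend on the group here. Having an aromatic ring at this carbon is clearly not enough to keep the low number, and nothing available explains the loss with phenyl. The compounds shown leave open whether a pyridyl or furyl group would behave like 1,3-thiazol-2-yl or like phenyl.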